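The source may report more compounds than this note shows. Statements on the series, on what has been measured and on what is new or still open speak of the compounds shown alone.

Measured so far:
Compound 1 `CNc1ccccc1N1CCN(CCCCn2ncc(=O)n(C)c2=O)CC1`, in an assay for displacement of a labelled ligand from Adrenergic receptor alpha-1 (Homo sapiens) (a lower number here means a stronger inhibitor, a higher number a weaker inhibitor), compound 1 gives 450 nM.
Compound 2 `Cn1c(=O)cnn(CCCCN2CCN(c3ccccc3C#N)CC2)c1=O`, in this assay compound 2 gives 7.3 nM.

Among the compounds with values here, compound 2 holds the lowest of the two numbers; the only step measured, a 62-fold lower number from compound 1 to compound 2 (1.79 log units; beyond the scatter), concerns a different change. Compound 3 `COc1ccc(N2CCN(CCCCn3ncc(=O)n(C)c3=O)CC2)c(C#N)c1` differs from compound 2 by methoxy in place of hydrogen on an aromatic carbon. Within the data shown here, no measured step bears on adding a group at this place, so no change beyond the scatter is expected, a 1.4-fold higher number from compound 2 to compound 3 (0.14 log units; within the scatter). Compound 3 is therefore estimated at 10 nM, in the range 3 nM to 30 nM.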

Compound 3, inhibition constant: 380 nM
Beside the measured number, compound 3's estimate is 38-fold (1.58 log units) below it, outside the stated range (above it).
By their numbers in this assay, from the lowest: compound 2; then compounds 3 and 1 (each within the scatter of the next).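

The carbon para to a large group and meta to a cyano group does not tolerate every addition: methoxy in place of hydrogen there gives a 52-fold higher number from compound 2 to compound 3 (1.72 log units; beyond the scatter) in this assay. Within the data shown here, the earlier step showed only that swapping one group for another on this ring matters, whereas this one shows that adding a group at a former hydrogen can matter just as much. Nothing available explains this loss. On these data alone, whether fluorine or a hydroxyl group at this carbon would fare the same remains open, as does whether methoxy has a similar effect alongside methylamino instead of cyano.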